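Benzofuran for Furan on Two Related Nucleoside Cores

A few compounds are considered here, and "the series" means these few. Any claim that something is new, unique, unknown or untested is made for them only; others in the source may bear on it.

Compound 1 `Cc1ncnc2c1c(-c1cc3ccccc3o1)cn2[C@@H]1O[C@H](CO)[C@@H](O)[C@H]1O` and compound 2 `Cc1ncnc2c1c(-c1ccoc1)cn2[C@@H]1O[C@H](CO)[C@@H](O)[C@H]1O` share one core, while compound 3 `Cc1nc(N)c2c(-c3ccoc3)cn([C@@H]3O[C@H](CO)[C@@H](O)[C@H]3O)c2n1` and compound 4 `Cc1nc(N)c2c(-c3cc4ccccc4o3)cn([C@@H]3O[C@H](CO)[C@@H](O)[C@H]3O)c2n1` share another; the difference between the two cores is not broken down here. In a functional assay on K562 cells (Homo sapiens), read by MTT assay, with a stated time of 72 h (on this read-out lower numbers stand for stronger inhibition and higher numbers for weaker inhibition), compound 1 gives 19500 nM. Compound 2 reaches only the limit of this assay, > 20000 nM. Compound 3 likewise reaches only the limit of this assay, > 20000 nM. The change from compound 2 to compound 1 is 1-benzofuran-2-yl in place of furan-3-yl on an aromatic carbon, and it made an at least 1.0-fold lower number from compound 2 to compound 1 (0.01 log units; that floor lies within the scatter); that floor rests on (the limit of > 20000 nM in this assay, at which 2 of the 3 values shown sit), so the true step may be larger than the floor shows. The change from compound 3 to compound 4 is 1-benzofuran-2-yl in place of furan-3-yl on an aromatic carbon; the place is described in the same words on both cores, so this is the same kind of change. The step is expected to be an at least 1.1-fold lower number from compound 3 to compound 4 (0.04 log units; that floor lies within the scatter), beside the earlier one, because compound 1 gives 19500 nM on its own core. Compound 4 is therefore estimated at 18000 nM, between 7000 nM and 45000 nM, with a fair chance that this assay reports only a limit.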

Compound 4, half-maximal inhibitory concentration: 15700 nM
For compound 4 the middle estimate is 1.1-fold (0.06 log units) above the measured one; measured number inside the range.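

In this assay, placing 1-benzofuran-2-yl in place of furan-3-yl on an aromatic carbon gave an at least 1.2-fold lower number from compound 3 to compound 4 (0.10 log units; that floor lies within the scatter). On the core of compound 1, the same change gave an at least 1.0-fold lower number from compound 2 to compound 1 (0.01 log units; that floor lies within the scatter), so the series offers a matching direction on both cores but no proof that the change carries over with the same size: the same change on two cores in this assay, an at least 1.0-fold lower number (0.01 log units; that floor lies within the scatter) from compound 2 to compound 1 and an at least 1.2-fold lower number (0.10 log units; that floor lies within the scatter) from compound 3 to compound 4; the limit leaves it open whether they differ. Among these compounds, neither step gives a true size, and both floors lie within the usual scatter, so the data show only that compound 1 and compound 4 return measured numbers while compound 2 and compound 3 stand at a limit: the limit of > 20000 nM in this assay, at which 2 of the 4 values shown sit.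

The compounds shown leave open how far compound 2 and compound 3 lie past that limit, and so whether the change does anything beyond the scatter on either core. They also leave open how a group of another kind on the same aromatic carbon, such as an amine, a carboxylic acid or a longer carbon chain, would read out on these two cores.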